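The source may report more compounds than this note shows. Statements on the series, on what has been measured and on what is new or still open speak of the compounds shown alone.

The series shares one core, seen in compound 1 `Cc1ccc(-c2ccc3[nH]c(=O)nc(-c4ccccc4)c3c2)cn1` and compound 2 `O=c1nc(-c2ccccc2)c2cc(-c3cccc(F)c3)ccc2[nH]1`, and is followed in an ADME assay on THP-1 cells (Homo sapiens) for cytotoxicity, read by MTT assay, with a stated time of 72 h; a lower number here means that less compound is needed, a higher number that more compound is needed for the effect. For compound 1 this assay reports only a limit, > 50000 nM. For compound 2 the result is again a limit, > 50000 nM. The step that the two limits leave unreadable from compound 1 to compound 2 therefore cannot be sized, because of the limit of > 50000 nM in this assay, at which 2 of the 2 values shown sit. Compound 2 thus stands at the limit of this assay, and nothing finer is shown for it. Compound 3 `Cc1ccc2[nH]c(=O)nc(-c3ccccc3)c2c1`, not yet measured, differs from compound 2 as follows: methyl in place of 3-fluorophenyl on an aromatic carbon. Among the compounds with values here, no measured step bears directly on this change; the one step recorded, from 6-methylpyridin-3-yl to 3-fluorophenyl, sits between two limits and gives no size. Compound 3 is therefore expected at the limit as well, the expected step being a step that the limit leaves unreadable from compound 2 to compound 3. The estimate for compound 3 in this assay is 60000 nM, within 20000 nM to 200000 nM.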

Compound 3, half-maximal effective concentration: > 50000 nM
Compound 3: no number, only a limit; the forecaster's own chance of this, stated with the estimate: 80%; the middle value lies beyond the limit too.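

No new step can be read between compound 3 and either compound 1 or compound 2 in this assay, because all three give only a limit: the limit of > 50000 nM in this assay, at which 3 of the 3 values shown sit. The compounds shown leave open what concentration gives the half-maximal effect for any of them, and whether methyl, 3-fluorophenyl and 6-methylpyridin-3-yl differ at all.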